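Methoxy in place of methyl: the step to compound 3

This account rests on a few compounds, and the source may have more. Where it says the series, first, only, none or still open, it means among the compounds named here.

Compound 1 `CC(=O)SCC(=O)c1ccc(NS(=O)(=O)c2cccc(F)c2)cc1` ("not determined" (no result reported))
Compound 2 `CC(=O)SCC(=O)c1ccc(NS(=O)(=O)c2ccc(C)cc2)cc1` (6500 nM)

For the measured compounds named here, in a functional assay on HCT-116 cells (Homo sapiens) for cytotoxicity (a higher number here means that more compound is needed for the effect, a lower number that less compound is needed), compound 2 gives 6500 nM, the only number available, and compound 1 has no result to compare it with. Compound 3 `COc1ccc(S(=O)(=O)Nc2ccc(C(=O)CSC(C)=O)cc2)cc1` carries methoxy in place of methyl on an aromatic carbon, para to a large group (methoxy in place of methyl on an aromatic carbon). Going by the values given here, no measured step offers a guide, so no shift beyond the usual scatter is expected in this assay, in either direction. The expected size of the step is small (a 1.1-fold lower number from compound 2 to compound 3 (0.03 log units; within the scatter)). For compound 3 the estimated value is 6000 nM, with an expected range from 2000 nM to 18000 nM in this assay's read-out.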

Compound 3, half-maximal effective concentration: 500 nM
The estimate for compound 3 lay 12-fold (1.08 log units) above the measured number; the whole stated range lies above it.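

At this aromatic carbon, para to a large group, the change from 4-methylphenyl to 4-methoxyphenyl gives, in this assay, a 13-fold lower number from compound 2 to compound 3 (1.11 log units; beyond the scatter), so the position is far from indifferent to what stands on it. The step adds one oxygen and one hydrogen-bond acceptor, and nothing available explains why the number moves so far.

With a single step at this place, the compounds shown leave open whether the oxygen itself matters. Going by these compounds, how a hydroxyl, an amine or a longer ethoxy chain would read there also remains open.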